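Swapping sec-Butyl for a Trifluoromethylbenzyl Group on Indole Nitrogen

A few compounds are considered here, and "the series" means these few. Any claim that something is new, unique, unknown or untested is made for them only; others in the source may bear on it.

Compound 2 `CCC(C)n1ccc2cc(/C(C)=C/C(=O)Nc3ccccc3OCCCC(=O)O)ccc21` stands lowest of the two numbers in an assay on Prostate gland for inhibition of steroid 5-alpha-reductase (Rattus norvegicus) (a higher number here means a weaker inhibitor, a lower number a stronger inhibitor), giving 67 nM. Compound 1 `C/C(=C\C(=O)Nc1ccccc1OCCCC(=O)O)c1ccc2c(ccn2CC(C)C)c1` gives 160 nM, so a 2.4-fold lower number from compound 1 to compound 2 (0.38 log units; beyond the scatter). Compound 3 `C/C(=C\C(=O)Nc1ccccc1OCCCC(=O)O)c1ccc2c(ccn2Cc2ccc(C(F)(F)F)cc2)c1` differs from compound 2 by 4-(trifluoromethyl)benzyl in place of sec-butyl on an aromatic nitrogen. Within the data shown here, only the step from compound 1 to compound 2 bears on this position, and it was modest; no measured pair replaces sec-butyl with 4-(trifluoromethyl)benzyl there, so the direction is open. Compound 3 is therefore expected to give 55 nM, with a range from 15 nM to 200 nM. The expected step is a 1.2-fold lower number from compound 2 to compound 3 (0.09 log units; within the scatter), small in either direction.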

Compound 3, half-maximal inhibitory concentration: 300 nM
The estimate for compound 3 lay 5.5-fold (0.74 log units) below the measured number; the measured number lies above the stated range.
By their numbers in this assay, from the lowest: compound 2; then compounds 1 and 3 (each within the scatter of the next).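

In this assay, 4-(trifluoromethyl)benzyl on the aromatic nitrogen gives a 4.5-fold higher number from compound 2 to compound 3 (0.65 log units; beyond the scatter), so this position does not hold its lowest number when sec-butyl gives way to this larger, ring-bearing group. Against isobutyl the same group gives a 1.9-fold higher number from compound 1 to compound 3 (0.27 log units; within the scatter), which leaves sec-butyl alone apart from the other two groups. Nothing at hand explains this difference.

Still open, as far as these compounds go, is whether the benzyl ring or its trifluoromethyl group accounts for the step from sec-butyl, which plain benzyl would test. From the compounds shown here alone, whether cyclopentyl, a branched ring-bearing chain, would keep the number of compound 2 is also open.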